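From a Benzylamine to a Urea on the Shared Core

This account rests on a few compounds, and the source may have more. Where it says the series, first, only, none or still open, it means among the compounds named here.

Going by the values given here, compound 1, `COc1ccc(S(=O)(=O)N2CCc3cc(Br)cc(NC(=O)c4ccco4)c32)cc1`, is the only compound here with a numerical result. In a functional assay on MKN-45 cells (Homo sapiens) for cytotoxicity (a lower number here means a stronger inhibitor, a higher number a weaker inhibitor), compound 1 gives 78 nM. Compound 2, `COc1ccc(S(=O)(=O)N2CCc3cccc(NCc4ccccc4)c32)cc1`, shares the core but differs in the groups attached to it. In this assay compound 2 gives > 10000 nM, which is a limit of the assay and not a number. Of the values shown, (the limit of > 10000 nM in this assay, at which 1 of the 2 values shown sits). Compound 3, `COc1ccc(S(=O)(=O)N2CCc3cccc(NC(=O)N(C)c4ccccc4)c32)cc1`, has not yet been measured. It differs from compound 2 in one place: methyl(phenyl)carbamoyl in place of benzyl on a nitrogen on an aromatic ring. Among the compounds with values here, no step between two measured compounds is available, so the size of this change can only be guessed. The expectation of a gain rests on compound 1, which carries a carbonyl on the same kind of nitrogen and gives 78 nM in this assay, although the bromine of compound 1 is absent in compound 3. The step from compound 2 to compound 3 is therefore expected to be a move toward stronger inhibition, roughly an at least 3.3-fold lower number from compound 2 to compound 3 (0.52 log units; beyond the scatter). Compound 3 is expected to give 3000 nM, within a range from 400 nM to 10000 nM.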

Compound 3, half-maximal inhibitory concentration: > 10000 nM
Compound 3: no number, only a limit (the forecaster's own chance of this, stated with the estimate: 35%); middle value at least 3.3-fold (0.52 log units) away from the limit.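

In this assay compound 3 gives > 10000 nM, which is a limit of the assay and not a number. Going by these compounds alone, compound 2 also stands at a limit, and no step from compound 2 to compound 3 can be read. The compounds shown leave open whether methyl(phenyl)carbamoyl in place of benzyl changes the inhibition at all.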